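This account rests on a few compounds, and the source may have more. Where it says the series, first, only, none or still open, it means among the compounds named here.

Compound 2 `Cc1cn(C2CCN(Cc3cccc(Oc4ccc(F)c(F)c4)c3)CC2)c(=O)[nH]c1=O` is one of two closely related compounds tested in an ADME assay on MRC5 cells (Homo sapiens) for cytotoxicity, read by fluorescence and resazurin assay, with a stated time of 3 days; a higher number here means a weaker inhibitor, a lower number a stronger inhibitor. In this assay compound 2 gives > 64000 nM, which is a limit of the assay rather than a number. Compound 1 `Cc1cccc(Oc2cccc(CN3CCC(n4cc(C)c(=O)[nH]c4=O)CC3)c2)c1` differs from compound 2 only at the oxygen on the aromatic ring, where it carries a 3-methylphenyl. In this assay compound 1 gives > 64000 nM, again a limit of the assay and not a number. The step that the two limits leave unreadable from compound 1 to compound 2 therefore cannot be read, since both values sit at the limit of > 64000 nM in this assay, at which 2 of the 2 values shown sit. Compound 3 `Cc1cn(C2CCN(Cc3cccc(Oc4ccc(Cl)c(Cl)c4)c3)CC2)c(=O)[nH]c1=O` has not yet been measured; it differs from compound 2 as follows: 3,4-dichlorophenyl in place of 3,4-difluorophenyl on an oxygen on an aromatic ring. No measured step bears on this change, and no step size can be drawn from the shown values. The expected step that the limit leaves unreadable from compound 2 to compound 3 is accordingly none beyond the scatter. Compound 3 is thus estimated to give 80000 nM, within a range from 30000 nM to 250000 nM, most probably reported once more as a limit.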

Compound 3, half-maximal inhibitory concentration: 6100 nM
Beside the measured number, compound 3's estimate is 13-fold (1.12 log units) above it; measured number below the stated range.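

Placing the 3,4-dichlorophenyl where the 3,4-difluorophenyl stood gives an at least 10-fold lower number from compound 2 to compound 3 (1.02 log units; beyond the scatter) in this assay, so a lower number, meaning stronger inhibition of these cells, does appear with a change at this position. The comparison with the 3-methylphenyl points the same way, with an at least 10-fold lower number from compound 1 to compound 3 (1.02 log units; beyond the scatter). The step between compound 1 and compound 2 cannot be read, and both of these compounds stay at a limit of the assay rather than a number: the limit of > 64000 nM in this assay, at which 2 of the 3 values shown sit.

The compounds shown do not tell whether both chlorines are needed for this drop, or whether a phenyl with a single chlorine would give it too. They also leave open how a bromine or a trifluoromethyl group on this ring would read in this assay.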